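The source may report more compounds than this note shows. Statements on the series, on what has been measured and on what is new or still open speak of the compounds shown alone.

Measured compounds:
Compound 1, `COc1ccc(N2CCN(c3ncnc4scc(-c5ccc(Cl)cc5)c34)CC2)cc1`, gives 48.5 nM in a functional assay on MCF7 cells (Homo sapiens) for cytotoxicity, read by sulforhodamine B assay, with a stated time of 48 h; on this read-out higher numbers stand for weaker inhibition and lower numbers for stronger inhibition.
Compound 2, `COc1ccc(N2CCN(c3ncnc4scc(-c5ccc([N+](=O)[O-])cc5)c34)CC2)cc1`, gives 36.9 nM in this assay.
Compound 3, `O=C1c2ccccc2C(=O)N1Nc1ncnc2scc(-c3ccc(Cl)cc3)c12`, gives 39.3 nM in this assay.

Compound 1 and compound 2 differ by one change, (nitro in place of chloro on an aromatic carbon), and in this assay that change gave a 1.3-fold lower number from compound 1 to compound 2 (0.12 log units; within the scatter). Compound 3 carries a different core from compound 1; the difference between the two cores is not broken down here. Compound 4, `O=C1c2ccccc2C(=O)N1Nc1ncnc2scc(-c3ccc([N+](=O)[O-])cc3)c12`, is made from compound 3 by the same change, (nitro in place of chloro on an aromatic carbon), at a place described in the same words, so it counts as the same change. The step from compound 3 to compound 4 is estimated as a 1.3-fold lower number from compound 3 to compound 4 (0.10 log units; within the scatter) because the same change gave a 1.3-fold lower number from compound 1 to compound 2 (0.12 log units; within the scatter). On that basis compound 4 is expected to give about 31 nM in this assay, most likely between 12 nM and 80 nM.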

Compound 4, half-maximal inhibitory concentration: 107 nM
Compound 4: the middle estimate sits 3.5-fold (0.54 log units) below what was measured; measured number outside the range, above it.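

In this assay, replacing 4-chlorophenyl with 4-nitrophenyl gave a 2.7-fold higher number from compound 3 to compound 4 (0.43 log units; beyond the scatter), a result that differs from what the same change did on the core of compound 1. The two steps do not agree, so the change did not carry over unchanged from one core to the other: the same change on two cores in this assay, a 1.3-fold lower number (0.12 log units; within the scatter) from compound 1 to compound 2 and a 2.7-fold higher number (0.43 log units; beyond the scatter) from compound 3 to compound 4, 3.6-fold (0.55 log units) apart, beyond the scatter of two such steps. Going by these compounds alone, with only one pair on each core, this shows that the size and direction of the step depended on the core in these four compounds, but it does not show which part of the core is responsible, or why.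

The compounds shown leave open how an amine or a carboxylic acid in place of chloro would behave on either core. They also leave open whether the two cores would diverge in the same way with those groups.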